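The source may report more compounds than this note shows. Statements on the series, on what has been measured and on what is new or still open speak of the compounds shown alone.

Working notes on the chloroalkanamide series, a functional assay on HT-29 cells (Homo sapiens) for antiproliferative activity, with a stated time of 48 h; on this read-out higher numbers stand for weaker inhibition and lower numbers for stronger inhibition.

Compound 1 `CCCCC(OC)c1cccc(NC(=O)CCl)c1` gives 13000 nM in this assay. Compound 2 `O=C(CCCl)Nc1ccc(I)cc1` gives 18000 nM, a value within the usual scatter of that of compound 1. The difference between the cores of compound 1 and compound 2 is not broken down here. Compound 3 `CCCCC(OC)c1cccc(NC(=O)CCCl)c1` is reported only as a limit of this assay, > 100000 nM.

For the measured compounds named here, the one measured step is chloromethyl in place of chloro on a saturated chain carbon bound to a carbonyl carbon, which gave an at least 7.6-fold higher number from compound 1 to compound 3 (0.88 log units; beyond the scatter); the step is stated as a lower bound because of the limit of > 100000 nM in this assay, at which 1 of the 3 values shown sits.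

Compound 4 `O=C(CCCCl)Nc1ccc(I)cc1` is not yet measured. It differs from compound 2 by chloromethyl in place of chloro on a saturated chain carbon, two bonds along the chain from a carbonyl carbon. This is the same kind of change as from compound 1 to compound 3, but the place is not the same: in the measured pair the carbon is bound to a carbonyl carbon, whereas in compound 4 it is two bonds along the chain from a carbonyl carbon. The expectation is a weakening of comparable direction, estimated as a 3.9-fold higher number from compound 2 to compound 4 (0.59 log units; beyond the scatter), resting on compound 2 at 18000 nM and on the measured step of an at least 7.6-fold higher number from compound 1 to compound 3 (0.88 log units; beyond the scatter). Compound 4 is therefore expected near 70000 nM, between 25000 nM and 200000 nM, with a real chance that only a limit is reported.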

Compound 4, half-maximal inhibitory concentration: > 100000 nM
Compound 4 ended at the assay's limit; the forecaster's own chance of this, stated with the estimate: 50%; at least 1.4-fold (0.15 log units) between middle value and limit.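

Chloromethyl in place of chloro on the chain gives an at least 5.5-fold higher number from compound 2 to compound 4 (0.74 log units; beyond the scatter) in this assay, so the weakening seen on the core of compound 1 also appears on the core of compound 2. Set side by side, the two steps read: the same change on two cores in this assay, an at least 7.6-fold higher number (0.88 log units; beyond the scatter) from compound 1 to compound 3 and an at least 5.5-fold higher number (0.74 log units; beyond the scatter) from compound 2 to compound 4; the limit leaves it open whether they differ. Both steps rest on a limit and not on a measured number, so the direction of the change carries over between these two cores, while its full size on either core and any difference between them stay unresolved: the limit of > 100000 nM in this assay, at which 2 of the 4 values shown sit.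

The compounds shown leave open whether a chain with bromo in place of chloro, or with an amine in place of chloro, would retain the activity of the shorter chloroalkanamides. They also leave open whether a longer chain than 3-chloropropyl, or a chain without chlorine, would give a value that can be read as a number in this assay.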